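The source may hold more compounds than are shown below. What is called first, only, known or untested is meant among the compounds shown, and "the series" means these compounds.

Measured so far:
compound 1 `CCCCCCNC(=O)n1cc(C)c(=O)[nH]c1=O`, in an assay on HEK293 cells for inhibition of acid ceramidase (Rattus norvegicus), read by LC-MS, with a stated time of 30 min (on this read-out higher numbers stand for weaker inhibition and lower numbers for stronger inhibition), compound 1 gives 1460 nM
compound 2 `CCCCCCNC(=O)n1cc(F)c(=O)n(CC2CC2)c1=O`, in this assay compound 2 gives 61 nM

Of these two numbers, compound 2 holds the lower one, and the gap to compound 1 lies well beyond the scatter. Compound 3 `CCCCCCNC(=O)n1cc(F)c(=O)n(C(=O)c2ccccc2)c1=O` differs from compound 2 only by benzoyl in place of cyclopropylmethyl on an aromatic nitrogen. Within the data shown here, no measured pair shows a change of this kind, so the size of the step is open. A step of a 2.5-fold higher number from compound 2 to compound 3 (0.39 log units; beyond the scatter) is expected as a modest loss, possibly not beyond the scatter. Compound 3 is estimated at 150 nM, within a range from 40 nM to 600 nM.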

Compound 3, half-maximal inhibitory concentration: 20 nM
The estimate for compound 3 lay 7.5-fold (0.88 log units) above the measured number; measured number outside the range, below it.
By their numbers in this assay, from the lowest: compound 3; then compound 2; then compound 1.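

In this assay, benzoyl in place of cyclopropylmethyl on the aromatic nitrogen gives a 3.1-fold lower number from compound 2 to compound 3 (0.48 log units; beyond the scatter), a modest gain beyond the scatter. Among these compounds, this position therefore takes a larger group carrying a six-membered aromatic ring and a carbonyl with no loss of inhibition, which the earlier compounds could not show. Nothing at hand bears on why the number falls. As far as these compounds go, whether the aromatic ring or the carbonyl carries the step stays open, since both enter together. A benzyl or an acetyl group on this nitrogen would separate the two.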